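The compounds below may be only part of what the source reports. "The series", "measured", "known", "first", "only" and "open" are said of these compounds alone.

Measured compounds:
- Compound 1, `Cc1nc(OCc2c(-c3c(Cl)cccc3Cl)noc2C(C)C)ccc1N(C)C(=O)c1ccc(C(=O)O)cc1`: 1190 nM
- Compound 2, `CN(Cc1cccc(C(=O)O)c1)c1ccc(OCc2c(-c3c(Cl)cccc3Cl)noc2C2CC2)nc1C(F)(F)F`: 2 nM
- Compound 3, `CC(c1ccc(OCc2c(-c3c(Cl)cccc3Cl)noc2C2CC2)nc1C(F)(F)F)N(C)c1ccc(C(=O)O)cc1`: 182 nM

All three were tested in a functional assay on HEK293 cells for agonist activity at Bile acid receptor (Homo sapiens), read by a luciferase reporter; on this read-out higher numbers stand for an effect only at larger amounts of compound and lower numbers for an effect already at smaller amounts. Among the three numbers, compound 3 stands second highest with 182 nM. Its nearest neighbour is compound 1, whose 1190 nM lies beyond the usual scatter above it, and the furthest is compound 2, whose 2 nM lies far below it, also beyond the scatter. Compound 2 and compound 3 share the same core and differ in more than one place, so nothing can be said about which part of that difference matters.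

The next compound, compound 4, `CC(Oc1cccc(C(=O)O)c1)c1ccc(OCc2c(-c3c(Cl)cccc3Cl)noc2C2CC2)nc1C(F)(F)F`, keeps the core of compound 3 and changes one part of it: 3-carboxyphenoxy in place of (4-carboxyphenyl)(methyl)amino on a saturated chain carbon bound to an aromatic carbon and a saturated chain carbon. For the measured compounds named here, no measured pair shows this kind of change on its own, so there is no step to lean on. The expectation for this assay is a small step from compound 3 to compound 4, a 1.8-fold lower number from compound 3 to compound 4 (0.26 log units; within the scatter), leaning toward a lower number but possibly within the scatter. Compound 4 is estimated at 100 nM, with a plausible range from 15 nM to 700 nM.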

Compound 4, half-maximal effective concentration: 58 nM
Estimate against measurement, compound 4: 1.7-fold (0.24 log units) above; measured number inside the range.
By their numbers in this assay, from the lowest: compound 2; then compound 4; then compound 3; then compound 1.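

In this assay, for the compounds shown here, placing 3-carboxyphenoxy instead of (4-carboxyphenyl)(methyl)amino on the saturated chain carbon gives a 3.1-fold lower number from compound 3 to compound 4 (0.50 log units; beyond the scatter) and is the first direct sign that this carbon accepts more than one acid-bearing aromatic group without a loss. Compared with the different arm on the aromatic carbon of the shared core, 1-(3-carboxyphenoxy)ethyl in place of (3-carboxybenzyl)(methyl)amino gives a 29-fold higher number from compound 2 to compound 4 (1.46 log units; beyond the scatter) in this assay, so this new arm, though better than the one it replaced in compound 3, still falls well short of the arm in compound 2. No measurement is available here that explains either step.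

The step from compound 3 to compound 4 swaps the linking nitrogen for oxygen and also changes where the carboxyl group sits on the ring, so these two changes cannot be separated, and neither can the arm's several differences between compound 2 and compound 4. Going by these compounds, it also remains open whether a tetrazole could stand in for the carboxylic acid on this arm and keep the effect at similarly small amounts of compound.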